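A few compounds are considered here, and "the series" means these few. Any claim that something is new, unique, unknown or untested is made for them only; others in the source may bear on it.

Working notes on a small series examined in a functional assay on the whole organism (Central nervous system) for activation, with Mus musculus as the target; a higher number here means that more compound is needed for the effect, a lower number that less compound is needed. Compound 1 `Cc1ccc(C23CCC(=O)N2CCCO3)c(C)c1` gives in this assay a reading that is a limit of the method, < 50 mg/kg. Compound 3 `O=C1CCCC2(c3ccccc3)OCCCN12` likewise gives in this assay a limit, < 50 mg/kg. Within the data shown here, compound 2 `O=C(CCC(=O)c1ccc(F)cc1)NCCCO` is the one member with an actual number in this assay, 300 mg/kg, and so stands as the only fixed point in the set. The two remaining values sit at the limit of < 50 mg/kg in this assay, at which 2 of the 3 values shown sit, so no ordering between compound 2 and either of the others can be read from them.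

Compound 4 `Cc1ccc(C(=O)CCC(=O)NCCCO)cc1` has not yet been measured. It differs from compound 2 by methyl in place of fluoro on an aromatic carbon. Among the measured compounds shown here, no pair of measured compounds differing in a single place is available, so no measured step anchors this change in this assay. The expectation is a step of no size beyond the usual scatter, in either direction. Compound 4 is accordingly estimated at 250 mg/kg, within a range of 100 mg/kg to 600 mg/kg. The step expected, a 1.2-fold lower number from compound 2 to compound 4 (0.08 log units; within the scatter), is therefore a small one.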

Compound 4, dose for half-maximal effect: 300 mg/kg
Compound 4: the middle estimate sits 1.2-fold (0.08 log units) below what was measured, within the range that was stated.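

Methyl in place of fluoro on an aromatic carbon, para to a large group, gives in this assay no change at the digits printed from compound 2 to compound 4 (within the scatter). Among these compounds, this is the only measured step that differs in one place, and compound 2 is no longer the sole fixed point, since compound 4 now stands beside it with an actual number. At this position the read-out does not separate these two groups, although that holds for this one pair and no further.

From the compounds shown here alone, whether an amine or a carboxylic acid at the same position, or a longer chain in place of methyl, would move the number stays open. Compounds 1 and 3 differ from this pair in more than one place and give only limits, so they cannot be ordered against it: the limit of < 50 mg/kg in this assay, at which 2 of the 4 values shown sit.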